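The source may report more compounds than this note shows. Statements on the series, on what has been measured and on what is new or still open speak of the compounds shown alone.

Measured in a functional assay on SGC-7901 cells (Homo sapiens) for antiproliferative activity, read by MTT assay, with a stated time of 24 h; a lower number here means a stronger inhibitor, a higher number a weaker inhibitor:
- compound 1 `O=C(NNc1ccccc1Cl)c1cccc(NS(=O)(=O)c2cnc(O)nc2O)c1`: 2270 nM
- compound 2 `O=C(NNc1ccc(F)cc1)c1ccccc1NS(=O)(=O)c1cnc(O)nc1O`: > 20000 nM
- compound 3 `CCCCOc1ccc(C(=O)NNC(=O)c2ccc(NS(=O)(=O)c3cnc(O)nc3O)cc2)cc1`: 14700 nM

Compound 1 has the lowest of the two actual numbers in this set. Its nearest neighbour, compound 3, sits higher by more than the usual scatter. The entry for compound 2 is a limit of the assay, not a number.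

The next compound is compound 4 `O=C(NNC(=O)c1cccc(NS(=O)(=O)c2cnc(O)nc2O)c1)c1cccc(Cl)c1`, which has not yet been measured. It is reached from compound 1 by placing (3-chlorophenyl)carbonyl in place of 2-chlorophenyl on an amine nitrogen. Among the compounds with values here, no measured step isolates this change, so the expectation is tentative. Within the data shown here, compound 3, the only measured compound with a carbonyl on that nitrogen, gives 14700 nM, and this points to a weaker result in this assay, by a moderate step beyond the scatter. The expected change is a 3.1-fold higher number from compound 1 to compound 4 (0.49 log units; beyond the scatter). Compound 4 is estimated at 7000 nM, with an expected range of 2000 nM to 20000 nM.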

Compound 4, half-maximal inhibitory concentration: 7310 nM
The estimate for compound 4 lay 1.0-fold (0.02 log units) below the measured number, within the range that was stated.
By their numbers in this assay, from the lowest: compound 1; then compounds 4 and 3 (each within the scatter of the next). At a limit, above all of these: compound 2.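

In this assay, within the data shown here, the change on this amine nitrogen gives the first direct reading at this position, a 3.2-fold higher number from compound 1 to compound 4 (0.51 log units; beyond the scatter), so (3-chlorophenyl)carbonyl gives a weaker result here than 2-chlorophenyl, though compound 4 still returns an actual number rather than a limit. The step joins two differences, the added carbonyl and the move of the chlorine, and this single pair cannot apportion the shift between them. Nothing measured in this set explains the shift.

The compounds shown leave open which of the two differences carries the step, a question that (2-chlorophenyl)carbonyl or plain 3-chlorophenyl on the same nitrogen would address. They also leave open whether an unsubstituted benzoyl group or a short alkyl carbonyl such as acetyl would behave like the chlorinated group.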